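Notes on a biphenyl ether series against SGC-7901 cells

The source may report more compounds than this note shows. Statements on the series, on what has been measured and on what is new or still open speak of the compounds shown alone.

Measured compounds:
- compound 1, `CC1=C(CCCCCCCCCCn2cc(C[C@H](O)COCCOC[C@@H](O)Cc3ccc(-c4ccccc4)cc3)nn2)C(=O)c2ccccc2C1=O`: 390 nM
- compound 2, `O[C@H](COCCOC[C@@H](O)Cc1cn(-c2ccc3c(c2)OCCO3)nn1)Cc1ccc(-c2ccccc2)cc1`: 6400 nM
- compound 3, `COC1=C(OC)C(=O)C(CCCCCCCCCCCCCCCn2cc(C[C@H](O)COCCOC[C@@H](O)Cc3ccc(-c4ccccc4)cc3)nn2)=C(C)C1=O`: 2490 nM

All three share the biphenyl-bearing diol ether chain and differ in what is attached to the five-membered aromatic ring with three nitrogen atoms. In a functional assay on SGC-7901 cells (Homo sapiens) for inhibition, read by MTT assay, with a stated time of 72 h (on this read-out higher numbers stand for weaker inhibition of growth and lower numbers for stronger inhibition of growth), compound 1 gives 390 nM, the lowest number of the set. Compound 3 gives 2490 nM in this assay, and compound 2 gives 6400 nM. Compound 2 thus stands at the highest number of the three; its gaps to compound 3 and to compound 1 both lie beyond the scatter, so it is the weakest of the measured compounds.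

Compound 4, `O[C@H](COCCOC[C@@H](O)Cc1cn(-c2cccnc2)nn1)Cc1ccc(-c2ccccc2)cc1`, is not yet measured. It differs from compound 2 in one place: pyridin-3-yl in place of 2,3-dihydro-1,4-benzodioxin-6-yl on an aromatic nitrogen. Both compounds carry a small aromatic group on the ring nitrogen rather than the long chain with a carbonyl-bearing core seen in compound 1 and compound 3. On these data alone, no direct comparison between compound 2 and compound 4 exists in the data, so the size of the step is unknown. The expectation is a step of no more than about the scatter, with no firm direction. Compound 4 is estimated at 7000 nM, within 2500 nM to 20000 nM, since the step of a 1.1-fold higher number from compound 2 to compound 4 (0.04 log units; within the scatter) is expected to be small.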

Compound 4, concentration for 50% growth inhibition: 29800 nM
Compound 4: the middle estimate sits 4.3-fold (0.63 log units) below what was measured; the whole stated range lies below it.
By their numbers in this assay, from the lowest: compound 1; then compound 3; then compound 2; then compound 4.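

In this assay the group on the aromatic nitrogen of the five-membered ring with 3 nitrogen proves sensitive even among small aromatic groups: pyridin-3-yl in place of 2,3-dihydro-1,4-benzodioxin-6-yl gives a 4.7-fold higher number from compound 2 to compound 4 (0.67 log units; beyond the scatter) as a modest step beyond the scatter. Within the data shown here, this is the only comparison in the set that changes one place, so the earlier compounds, which differ from each other in more than one place, could not isolate this position. The change removes a group of 10 heavy atoms with two rings and 2 hydrogen-bond acceptors and brings in a group of 6 heavy atoms with one ring and 1 hydrogen-bond acceptor, but no measurement here bears on which of these differences accounts for the higher number.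

On these data alone, it remains open whether naphthyl, with two rings of carbon only, would give a number closer to that of compound 2 than to that of compound 4. Also open, as far as these compounds go, is whether pyridin-4-yl at the same ring nitrogen would differ from pyridin-3-yl, which would show whether the place of the ring nitrogen matters.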